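Isopropyl in place of cyclopropyl on a ring amine

This account rests on a few compounds, and the source may have more. Where it says the series, first, only, none or still open, it means among the compounds named here.

For the measured compounds named here, in an ADME assay on microsomes from liver (Mus musculus) for metabolic stability, read by LC-MS, with a stated time of 10 min (a higher number here means that more of the compound is left, a lower number that less of the compound is left), compound 3 `CN(C[C@H]1Cc2c(cccc2N2CCN(C3CC3)CC2)CN1)[C@H]1CCCc2cccnc21` gives 7% and stands lowest of the three numbers measured so far. Compound 2 `CN(C[C@@H]1Cc2c(cccc2N2CCNCC2)CN1)[C@H]1CCCc2cccnc21` gives 54.6% and compound 1 `C[C@@H]1CN(c2cccc3c2C[C@H](CN(C)[C@H]2CCCc4cccnc42)NC3)C[C@H](C)N1` gives 85.6% and both lie beyond the scatter above it.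

The change to compound 4 `CC(C)N1CCN(c2cccc3c2C[C@H](CN(C)[C@H]2CCCc4cccnc42)NC3)CC1` is isopropyl in place of cyclopropyl on an amine nitrogen in a ring and puts isopropyl in place of cyclopropyl on an amine nitrogen in a ring. Going by the values given here, the only measured step that bears on it is a number 78.6 percentage points lower from compound 1 to compound 3 (beyond the scatter) and it is large. That step brought in 4-cyclopropylpiperazin-1-yl in place of 3,5-dimethylpiperazin-1-yl on an aromatic carbon, so it shows how far the number can move with a change on this part of the molecule. No measurement compares cyclopropyl with isopropyl directly. Compound 3 at 7% has little room left to fall, so any clear movement is more likely upward. The expected result is a number 6 percentage points higher from compound 3 to compound 4 (within the scatter) and this estimated step stays small. Compound 4 is expected to give 13% in this assay with an estimated range from 3% to 35% as its likely span.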

Compound 4, percent of the compound remaining: 15.1%
Compound 4: the middle estimate sits 2.1 percentage points below what was measured; the measured number falls inside the stated range.
By their numbers in this assay, from the lowest: compounds 3 and 4 (each within the scatter of the next); then compound 2; then compound 1.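

In this assay, isopropyl in place of cyclopropyl on the amine nitrogen of the ring gives a number 8.1 percentage points higher from compound 3 to compound 4 (within the scatter), so the two groups, with the same count of heavy atoms, cannot be told apart at this position. With 4-isopropylpiperazin-1-yl in place of 3,5-dimethylpiperazin-1-yl, the result is a number 70.5 percentage points lower from compound 1 to compound 4 (beyond the scatter). The large fall seen with the cyclopropyl group therefore also appears with a group that has no ring, and is not tied to the three-membered ring. Nothing at hand gives a reason for either result.

On these data alone, it remains open whether a methyl group, or an acetyl group forming an amide on this nitrogen, would leave more of the compound intact. Equally open, as far as these compounds go, is whether a hydroxyethyl chain there would do the same.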